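A Chlorine Added to the Phenyl Ring: What to Expect

The compounds below may be only part of what the source reports. "The series", "measured", "known", "first", "only" and "open" are said of these compounds alone.

Three compounds have so far been measured in a functional assay on SK-MEL-5 cells (Homo sapiens) for inhibition; on this read-out higher numbers stand for weaker inhibition of growth and lower numbers for stronger inhibition of growth:

Compound 1 `COc1cc(/C=C/C(=O)c2cccc(-n3cc(-c4ccc(Cl)cc4)[nH]c3=O)c2)cc(OC)c1OC` gives 8700 nM.
Compound 2 `COc1cc(/C=C/C(=O)c2cccc(-n3cc(-c4ccccc4)[nH]c3=O)c2)ccc1O` gives 1590 nM.
Compound 3 `O=C(/C=C/c1cccc(O)c1)c1cccc(-n2cc(-c3ccccc3)[nH]c2=O)c1` gives 3180 nM.

Compound 3 has the second highest number of the three. Its number lies within the scatter of compound 2, while compound 1 gives a higher number beyond the scatter. Compound 4 `O=C(/C=C/c1cccc(O)c1)c1cccc(-n2cc(-c3ccc(Cl)cc3)[nH]c2=O)c1` differs from compound 3 by chloro in place of hydrogen on an aromatic carbon. Among the compounds with values here, no measured step isolates this change: the only step, a 2.0-fold higher number from compound 2 to compound 3 (0.30 log units; within the scatter), concerns the other end of the molecule. Compound 1 also carries the chloro, yet it differs from compound 2 in two places, so its higher number cannot be assigned to the chloro alone. With no direct guide, compound 4 is expected to move a 1.4-fold higher number from compound 3 to compound 4 (0.15 log units; within the scatter), so compound 4 is estimated at 4500 nM, between 1500 nM and 14000 nM.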

Compound 4, concentration for 50% growth inhibition: 1530 nM
Compound 4: the middle estimate sits 2.9-fold (0.47 log units) above what was measured; the measured number falls inside the stated range.
By their numbers in this assay, from the lowest: compounds 4, 2 and 3 (each within the scatter of the next, the first and the last beyond it); then compound 1.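

Within the data shown here, this is the first direct reading of the chloro on this ring, para to a large group: in this assay the change gives a 2.1-fold lower number from compound 3 to compound 4 (0.32 log units; beyond the scatter), so here it goes with modestly stronger growth inhibition. Compound 1 also carries the chloro yet gives 8700 nM, so the chloro alone does not guarantee a low number. Nothing measured here explains the step. Going by these compounds, whether a fluoro, a methoxy or an amine at the same place would do as well remains open. So does whether the chloro gives a similar step with the 4-hydroxy-3-methoxyphenyl group of compound 2 at the other end.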